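Replacing Benzyloxy with tert-Butyl on the Amide Carbonyl

The source may report more compounds than this note shows. Statements on the series, on what has been measured and on what is new or still open speak of the compounds shown alone.

Of the compounds shown here, three sharing one core have been measured in an assay on COS-7 cells for inhibition of patatin-like phospholipase domain-containing protein 2 (Mus musculus); on this read-out higher numbers stand for weaker inhibition and lower numbers for stronger inhibition. Compound 1 `CN(C)c1ccc(-c2cccc([N+](=O)[O-])c2)cc1` gives only a limit of the assay, > 200000 nM. Compound 2 `COC(=O)Nc1cccc(-c2ccc(N(C)C)cc2)c1` gives 5000 nM, and the step of an at least 40-fold lower number from compound 1 to compound 2 (1.60 log units; beyond the scatter) is large. Compound 3 `CN(C)c1ccc(-c2cccc(NC(=O)OCc3ccccc3)c2)cc1` again returns only a limit, > 200000 nM. The step of an at least 40-fold higher number from compound 2 to compound 3 (1.60 log units; beyond the scatter) is the same size in the other direction, so compound 3 stands at the limit of > 200000 nM in this assay, at which 2 of the 3 values shown sit, together with compound 1, with no number of its own.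

Compound 4 `CN(C)c1ccc(-c2cccc(NC(=O)C(C)(C)C)c2)cc1` differs from compound 3 by tert-butyl in place of benzyloxy on a carbonyl carbon. For the measured compounds named here, the step that bears on this change is the one from compound 2 to compound 3, where adding a phenyl to the chain carbon bound to the carbonyl-side oxygen raised the number beyond the scatter. Removing the benzyloxy takes that phenyl away again, but what enters is a tert-butyl rather than the methoxy of compound 2, so the new compound resembles neither measured neighbour closely. The account therefore expects compound 4 to move downward from the limit by an at least 6.6-fold lower number from compound 3 to compound 4 (0.82 log units; beyond the scatter), while a return to the limit cannot be ruled out. The estimate for compound 4 in this assay is 30000 nM, with a range from 4000 nM to 200000 nM.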

Compound 4, half-maximal inhibitory concentration: > 200000 nM
Compound 4 ended at the assay's limit; the forecaster's own chance of this, stated with the estimate: 35%; middle value at least 6.6-fold (0.82 log units) away from the limit.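

Removing the benzyloxy with its aromatic ring does not by itself bring back a measurable value in this assay: compound 4, with tert-butyl on the same carbonyl carbon, still gives only a limit, and the steps from compound 3 and from compound 1 cannot be read, since both ends of each are limits. Exchanging methoxy for tert-butyl on the carbonyl carbon gives an at least 40-fold higher number from compound 2 to compound 4 (1.60 log units; beyond the scatter), so two different replacements of that methoxy, benzyloxy and tert-butyl, now both lose the measurable value seen with compound 2. Compound 2 remains the only one of the four compounds with a number of its own, and compound 4 joins compound 1 and compound 3 at the top of the read-out: the limit of > 200000 nM in this assay, at which 3 of the 4 values shown sit.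

As far as these compounds go, what stays open is whether the measurable value depends on the oxygen bound to the carbonyl carbon or on the shortness of the methoxy, since tert-butyl changes both at once. A plain methyl or an ethoxy on that carbonyl carbon would separate the two, and how far apart compound 1, compound 3 and compound 4 truly lie stays hidden behind their limits.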